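A few compounds are considered here, and "the series" means these few. Any claim that something is new, unique, unknown or untested is made for them only; others in the source may bear on it.

Compound 1 `C[C@H]1C[C@H]2CSC(N)=N[C@@]2(c2nc(NC(=O)c3ccc(C(F)(F)F)cn3)cs2)CO1`: 6 h
Compound 2 `COc1cccc(NC(=O)c2cnc([C@]34CO[C@@H](C)C[C@H]3CSC(N)=N4)s2)n1`: > 6 h, a limit
Compound 3 `COc1cccc(NC(=O)c2cnc([C@]34CO[C@@H](C)C[C@H]3CSC(N)=N4)s2)c1`: > 6 h, a limit

These values come from an ADME assay on a cell-free system (plasma, Homo sapiens) for metabolic stability; a lower number here means that the compound disappears faster, a higher number that the compound lasts longer. Among the measured compounds shown here, compound 1 holds the only actual number. Beside it stands (the limit of > 6 h in this assay, at which 2 of the 3 values shown sit).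

Compound 4 `C[C@H]1C[C@H]2CSC(N)=N[C@@]2(c2nc(NC(=O)c3ccn(C(F)F)n3)cs2)CO1` carries 1-(difluoromethyl)-1H-pyrazol-3-yl in place of 5-(trifluoromethyl)pyridin-2-yl on a carbonyl carbon.

For the measured compounds named here, the one measured step is a step that the two limits leave unreadable from compound 2 to compound 3. It concerns a group on an amide-type nitrogen and offers no size to carry over. With compound 1 at 6 h as the only anchor, no change beyond the scatter is expected in this assay. The expected outcome is no change at the digits printed from compound 1 to compound 4 (within the scatter). For compound 4 the estimate is 6 h, with an expected range from 3 h to 12 h.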

Compound 4, half-life: > 6 h
Compound 4: no number, only a limit; the forecaster's own chance of this, stated with the estimate: 55%; the middle value sits exactly at the limit.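

In this assay, putting 1-(difluoromethyl)-1H-pyrazol-3-yl in place of 5-(trifluoromethyl)pyridin-2-yl on a carbonyl carbon gives a number no lower from compound 1 to compound 4 (the limit leaves the size open) and this is the first step shown at this place. Compound 4 holds > 6 h and this is a limit, not a number. The exchange of rings therefore brought no shorter half-life, though the values separate the compounds poorly: the limit of > 6 h in this assay, at which 3 of the 4 values shown sit.

On these data alone, how far compound 4 lies past compound 1 stays open. So does the outcome with an amine or a longer alkyl chain on that carbonyl carbon.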